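The compounds below may be only part of what the source reports. "The series", "measured", "known", "first", "only" and "open" are said of these compounds alone.

Measured in a functional assay on A549 cells (Homo sapiens) for cytotoxicity, read by MTT assay, with a stated time of 72 h; on this read-out higher numbers stand for weaker inhibition and lower numbers for stronger inhibition:
- compound 1 (`COc1cccc(/C=C2\CCC/C(=C\c3cccc(O)c3)C2=O)c1OC`) gives > 20000 nM, a limit
- compound 2 (`COc1cccc(/C=C2\CCC/C(=C\c3ccc(O)cc3)C2=O)c1OC`) gives > 20000 nM, a limit
- compound 3 (`COc1cccc(/C=C2\CCC/C(=C\c3cccc(Cl)c3Cl)C2=O)c1OC`) gives > 20000 nM, a limit

Compound 3 has no number in this assay, only the limit > 20000 nM. It shares this position with the others, the series standing at the limit of > 20000 nM in this assay, at which 3 of the 3 values shown sit.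

The next compound is compound 4 (`COc1cccc(/C=C2\CCC/C(=C\c3ccc(Cl)cc3Cl)C2=O)c1OC`), which has the same atoms as compound 3, joined differently: 2,4-dichlorophenyl in place of 2,3-dichlorophenyl on a double-bonded chain carbon bound to a double-bonded ring carbon. The change puts 2,4-dichlorophenyl in place of 2,3-dichlorophenyl on a double-bonded chain carbon bound to a double-bonded ring carbon.

Among the compounds with values here, three measured steps concern this same place: a step that the two limits leave unreadable from compound 1 to compound 2, a step that the two limits leave unreadable from compound 1 to compound 3 and a step that the two limits leave unreadable from compound 2 to compound 3. None of them has a readable size, so none offers a size or direction to carry over. No step beyond the scatter is therefore expected in this assay.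

The expected step is a number no higher from compound 3 to compound 4 (the limit leaves the size open). For compound 4 the estimate is 20000 nM, with an expected range from 8000 nM to 40000 nM.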

Compound 4, half-maximal inhibitory concentration: > 20000 nM
Compound 4 ended at the assay's limit (the forecaster's own chance of this, stated with the estimate: 75%); the middle value lies on the limit itself.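

Compound 4 gives > 20000 nM, a limit, so its steps from compound 1, compound 2 and compound 3 cannot be read: the limit of > 20000 nM in this assay, at which 4 of the 4 values shown sit.

The compounds shown leave open whether any group on this double-bonded chain carbon gives a measurable value in this assay, and how these four compounds differ.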